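The source may hold more compounds than are shown below. What is called first, only, known or untested is meant among the compounds shown, and "the series" means these compounds.

Among the compounds with values here, compound 2 `Cc1ccccc1C(=O)Nc1ccc(S(=O)(=O)NC2CCN(C(=O)N3CCCCC3)CC2)c2ccccc12` is one of only two compounds measured in an assay on L1.2 cells for binding affinity to C-C chemokine receptor type 8 (Homo sapiens); on this read-out lower numbers stand for stronger inhibition and higher numbers for weaker inhibition. In this assay compound 2 gives 4.2 nM, the higher of the two numbers, while its nearest neighbour, compound 1 `Cc1ccccc1C(=O)Nc1ccc(S(=O)(=O)NC2CCN(C(=O)CN)CC2)c2ccccc12`, gives 4.1 nM, a gap that stays within the scatter. The two share the same core and differ only in the group attached to a carbonyl carbon: a 1.0-fold higher number from compound 1 to compound 2 (0.01 log units; within the scatter). Compound 3 `CCN(CC)CCCC(=O)N1CCC(NS(=O)(=O)c2ccc(NC(=O)c3ccccc3C)c3ccccc23)CC1` keeps everything of compound 2 except this same position; the change is 3-(diethylamino)propyl in place of piperidin-1-yl on a carbonyl carbon. Within the data shown here, the single measured step that touches this position, from compound 1 to compound 2, stayed within the scatter, so on the evidence of that one step alone the exchange of aminomethyl for piperidin-1-yl on this carbonyl carbon left the number unchanged. For the next exchange at the same place the step is therefore expected to be small, a 1.2-fold higher number from compound 2 to compound 3 (0.08 log units; within the scatter), with no clear direction beyond the scatter. Compound 3 is accordingly estimated at 5 nM in this assay, with a range from 2 nM to 15 nM.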

Compound 3, inhibition constant: 567 nM
The estimate for compound 3 lay 110-fold (2.05 log units) below the measured number; measured number above the stated range.
By their numbers in this assay, from the lowest: compounds 1 and 2 (each within the scatter of the next); then compound 3.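

This position is less forgiving than the first pair suggested: in this assay, 3-(diethylamino)propyl in place of piperidin-1-yl on the carbonyl carbon gives a 140-fold higher number from compound 2 to compound 3 (2.13 log units; beyond the scatter), whereas aminomethyl and piperidin-1-yl had stayed within the scatter of each other. The comparison with the other neighbour agrees, since 2-(diethylamino)ethyl in place of amino on the saturated chain carbon bound to a carbonyl carbon gives a 140-fold higher number from compound 1 to compound 3 (2.14 log units; beyond the scatter), so the group at this place can change the number strongly while the shared core stays untouched. Nothing available on these compounds accounts for the loss, and what in the new group is responsible remains unknown.

The compounds shown also leave open whether the large step goes with the diethylamino end, with the length of the chain, or with the absence of a ring at this place. A 3-aminopropyl group, which has a plain amine at the end of the same chain, and a butyl group, which has no amine at all, would help to tell these apart.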